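A few compounds are considered here, and "the series" means these few. Any claim that something is new, unique, unknown or untested is made for them only; others in the source may bear on it.

Measured compounds:
- compound 1, `C=C/C=C\[C@H](C)[C@H](OC(N)=O)[C@@H](C)[C@H](O)[C@@H](C)C/C(C)=C\[C@H](C)[C@@H](O)[C@@H](C)/C=C\CCc1ccccc1`: in a functional assay on MCF7 cells (Homo sapiens) for cytotoxicity (a higher number here means a weaker inhibitor, a lower number a stronger inhibitor), compound 1 gives 560 nM
- compound 2, `C=C/C=C\[C@H](C)[C@H](OC(N)=O)[C@@H](C)[C@H](O)[C@@H](C)C/C(C)=C\[C@H](C)[C@@H](O)[C@@H](C)/C=C\CCc1cccc(O)c1`: in this assay compound 2 gives 390 nM
- compound 3, `C=C/C=C\[C@H](C)[C@H](OC(N)=O)[C@@H](C)[C@H](O)[C@@H](C)C/C(C)=C\[C@H](C)[C@@H](O)[C@@H](C)/C=C\CCc1ccsc1`: in this assay compound 3 gives 4000 nM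

Compound 3 stands at the highest number of the three, the weakest inhibitor: the nearest is compound 1, with a 7.1-fold higher number from compound 1 to compound 3 (0.85 log units; beyond the scatter), and the furthest compound 2, with a 10-fold higher number from compound 2 to compound 3 (1.01 log units; beyond the scatter). Compound 1 and compound 2 lie within the scatter of each other, a 1.4-fold lower number from compound 1 to compound 2 (0.16 log units; within the scatter).

Compound 4, `C=C/C=C\[C@H](C)[C@H](OC(N)=O)[C@@H](C)[C@H](O)[C@@H](C)C/C(C)=C\[C@H](C)[C@@H](O)[C@@H](C)/C=C\CCc1cccc(Cl)c1`, is not yet measured. It differs from compound 3 by 3-chlorophenyl in place of thiophen-3-yl on a saturated chain carbon, two bonds along the chain from a double-bonded chain carbon.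

The relevant measured steps are the two that replace a six-membered carbon-only ring by thiophen-3-yl at this chain carbon; both raised the number beyond the scatter, the phenyl case modestly and the 3-hydroxyphenyl case by a large margin. Returning to a six-membered carbon-only ring, now carrying chlorine, is expected to run that step back, so a lower number is expected in this assay, of the order of the phenyl step reversed. Within the data shown here, no measured compound carries chlorine on the ring, so the width of the range is kept broad. The expected step is an 8.0-fold lower number from compound 3 to compound 4 (0.90 log units; beyond the scatter). Compound 4 is estimated at 500 nM, between 200 nM and 1300 nM.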

Compound 4, half-maximal inhibitory concentration: 650 nM
The estimate for compound 4 lay 1.3-fold (0.11 log units) below the measured number, and the stated range covers the measured number.
By their numbers in this assay, from the lowest: compounds 2, 1 and 4 (each within the scatter of the next); then compound 3.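

In this assay the high number of compound 3 is not tied to the hydroxy group of compound 2 or to an unsubstituted phenyl: 3-chlorophenyl in place of thiophen-3-yl also gives a lower number (a 6.2-fold lower number from compound 3 to compound 4 (0.79 log units; beyond the scatter)). On the six-membered carbon-only ring, this aromatic carbon tolerates chloro as well as hydrogen (a 1.2-fold higher number from compound 1 to compound 4 (0.06 log units; within the scatter)) and hydroxy (a 1.7-fold higher number from compound 2 to compound 4 (0.22 log units; within the scatter)), with both steps within the scatter, so these three substituents cannot be told apart here. Nothing available explains the step from thiophen-3-yl or this tolerance.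

Still open, from the compounds shown here alone, is whether an amine or a carboxylic acid in place of the chlorine would stay within the same scatter. Also open, going by these compounds, is whether 2-chlorophenyl, 4-chlorophenyl or pyridin-3-yl at this chain carbon would match 3-chlorophenyl or thiophen-3-yl.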